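The compounds below may be only part of what the source reports. "The series", "measured", "known", "first", "only" and "open" are said of these compounds alone.

In a functional assay on PC-3 cells (Homo sapiens) for cytotoxicity, read by MTT assay, with a stated time of 72 h (a lower number here means a stronger inhibitor, a higher number a weaker inhibitor), the measured compounds are:

Compound 1 `O=C(N/N=C/c1ccc(F)cc1)Nc1cc2c(Nc3ccc(F)c(Cl)c3)ncnc2cc1O[C@H]1CCOC1`: "not active" (no number reported)
Compound 2 `O=C(N/N=C/c1cccc(Br)c1)Nc1cc2c(Nc3ccc(F)c(Cl)c3)ncnc2cc1O[C@H]1CCOC1`: 15500 nM
Compound 3 `N#Cc1ccc(/C=N/NC(=O)Nc2cc3c(Nc4ccc(F)c(Cl)c4)ncnc3cc2O[C@H]2CCOC2)cc1`: 28100 nM

Only two of these results are numbers, and they cannot be told apart. For the measured compounds named here, the one measured step is a 1.8-fold higher number from compound 2 to compound 3 (0.26 log units; within the scatter), so compound 3 stands level with its only numbered neighbour.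

Compound 4 `O=C(N/N=C/c1ccc([N+](=O)[O-])cc1)Nc1cc2c(Nc3ccc(F)c(Cl)c3)ncnc2cc1O[C@H]1CCOC1` is still to be measured. It keeps the shared core and differs from compound 3 at one place, with nitro in place of cyano on an aromatic carbon, para to a large group: nitro in place of cyano on an aromatic carbon.

Going by the values given here, no measured step makes this exchange. The nearest evidence is the step above, which also changes the group on the same aromatic ring and stays within the scatter. A step beyond the scatter in this assay is therefore not expected, and no direction is favoured. The estimated step is a 1.3-fold lower number from compound 3 to compound 4 (0.11 log units; within the scatter). A result without a number also remains possible, as compound 1 gave "not active" (no number reported). For compound 4 the estimated value is 22000 nM, with an expected range from 10000 nM to 50000 nM.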

Compound 4, half-maximal inhibitory concentration: 33500 nM
Compound 4: the middle estimate sits 1.5-fold (0.18 log units) below what was measured, and the stated range covers the measured number.
By their numbers in this assay, from the lowest: compounds 2, 3 and 4 (each within the scatter of the next, the first and the last beyond it).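

In this assay, the exchange of cyano for nitro on an aromatic carbon, para to a large group, gives a 1.2-fold higher number from compound 3 to compound 4 (0.08 log units; within the scatter), so the two groups cannot be told apart at this position. The swap of 3-bromophenyl for 4-nitrophenyl gives a 2.2-fold higher number from compound 2 to compound 4 (0.33 log units; beyond the scatter), the only step among these compounds beyond the scatter, though a modest one; it changes both the group and where it sits on the ring, and compound 3 lies within the scatter of both compound 2 and compound 4. No measured evidence accounts for these results.

The shown compounds leave open whether an amine, a carboxylic acid or a methoxy group on the same aromatic carbon would give a clearly different number. From the compounds shown here alone, it also remains open where compound 1, with its result of "not active" (no number reported), stands relative to the others.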